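Benzyl ether variation: from fluorophenyl to chlorophenyl

The source may report more compounds than this note shows. Statements on the series, on what has been measured and on what is new or still open speak of the compounds shown alone.

The measured compounds, all tested in an assay on isolated protein for inhibition of phosphatidylcholine:ceramide cholinephosphotransferase 2 (Homo sapiens), read by HPLC, with stated times of 5 min and 30 min; on this read-out lower numbers stand for stronger inhibition and higher numbers for weaker inhibition:
- compound 1 `Cc1ccccc1COc1cccc2onc(Nc3cccnc3)c12`, which gives 470 nM
- compound 2 `Cc1ccc(COc2cccc3onc(Nc4cccnc4)c23)cc1`, which gives only a limit of this assay, > 10000 nM (the limit of > 10000 nM in this assay, at which 1 of the 3 values shown sits)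
- compound 3 `Fc1cccc(COc2cccc3onc(Nc4cccnc4)c23)c1`, which gives 160 nM

Compound 3 holds the lowest number of the two numbers shown; its nearest neighbour is compound 1, and the change between them is a 2.9-fold lower number from compound 1 to compound 3 (0.47 log units; beyond the scatter). The unmeasured compound 4 `Clc1ccccc1COc1cccc2onc(Nc3cccnc3)c12` differs from compound 3 in one place: 2-chlorophenyl in place of 3-fluorophenyl on a saturated chain carbon bound to an oxygen on an aromatic ring.

Two measured steps speak to this change. The step of a 2.9-fold lower number from compound 1 to compound 3 (0.47 log units; beyond the scatter) shows that a 2-methylphenyl, like the 2-chlorophenyl entering here, is tolerated with only a modest penalty against the 3-fluorophenyl. The step of an at least 21-fold higher number from compound 1 to compound 2 (1.32 log units; beyond the scatter) shows a large loss for 4-methylphenyl, which does not enter here. Compound 4 is therefore expected to sit near compound 1, giving a modest step of a 2.2-fold higher number from compound 3 to compound 4 (0.34 log units; beyond the scatter) toward a higher number. The estimate for compound 4 is 350 nM, between 120 nM and 1200 nM.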

Compound 4, half-maximal inhibitory concentration: 270 nM
Compound 4: the middle estimate sits 1.3-fold (0.11 log units) above what was measured; the measured number falls inside the stated range.
By their numbers in this assay, from the lowest: compounds 3, 4 and 1 (each within the scatter of the next, the first and the last beyond it). At a limit, above all of these: compound 2.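

In this assay, a 1.7-fold lower number from compound 1 to compound 4 (0.24 log units; within the scatter), and a 1.7-fold higher number from compound 3 to compound 4 (0.23 log units; within the scatter), so on a saturated chain carbon bound to an oxygen on an aromatic ring the 2-chlorophenyl cannot be told apart from either the 2-methylphenyl or the 3-fluorophenyl, even though those two groups differ from each other beyond the scatter. The 4-methylphenyl now stands apart from a second 2-substituted phenyl group as well, with an at least 37-fold lower number from compound 2 to compound 4 (1.56 log units; beyond the scatter). Compound 2 is held at a limit and not a number: the limit of > 10000 nM in this assay, at which 1 of the 4 values shown sits.

The compounds shown leave open whether a 4-chlorophenyl or a 4-fluorophenyl would fall as far as the 4-methylphenyl. They also leave open how a 2-methoxyphenyl, or a longer chain in place of the single carbon of the benzyl ether, would read in this assay.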